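Removing one tetrazolyl group from compound 2

A few compounds are considered here, and "the series" means these few. Any claim that something is new, unique, unknown or untested is made for them only; others in the source may bear on it.

Compound 1 `O=C(O)c1cc(NC(=O)c2cc(O)cc(O)c2)cc(C(=O)O)c1` gives 90.2 mg/kg
Compound 2 `O=C(Nc1cccc(-c2nn[nH]n2)c1)c1cccc(-c2nn[nH]n2)c1` gives 15.8 mg/kg
Compound 3 `O=C(O)c1cc(NC(=O)c2ccc(-c3nn[nH]n3)cc2)cc(C(=O)O)c1` gives 8.2 mg/kg

In a functional assay on the whole organism (stomach) with Rattus norvegicus as the target (on this read-out higher numbers stand for an effect only at larger amounts of compound and lower numbers for an effect already at smaller amounts), compound 2 holds the second highest of the three numbers. Its value and that of compound 3 lie within the scatter of each other, while compound 1 has a number well beyond the scatter from that of compound 2.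

Compound 4 `O=C(Nc1ccccc1)c1cccc(-c2nn[nH]n2)c1` has not yet been measured. It differs from compound 2 by one change, hydrogen in place of 2H-tetrazol-5-yl on an aromatic carbon, and it keeps the other 2H-tetrazol-5-yl group. Within the data shown here, no pair of measured compounds differs in only one place, so the size of this step cannot be read directly from the data. The only hint is a loose one. Compound 1, which has no 2H-tetrazol-5-yl group, stands at 90.2 mg/kg, and compound 3, which has one, stands at 8.2 mg/kg, but these two also differ elsewhere. On that basis a moderate move towards a higher number is expected, the estimated 2.2-fold higher number from compound 2 to compound 4 (0.35 log units; beyond the scatter). For compound 4 the expected value is 35 mg/kg, with an estimated range from 10 mg/kg to 120 mg/kg.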

Compound 4, dose for 50% inhibition: 38.1 mg/kg
Estimate against measurement, compound 4: 1.1-fold (0.04 log units) below; low and high end bracket the measured number.
By their numbers in this assay, from the lowest: compounds 3 and 2 (each within the scatter of the next); then compound 4; then compound 1.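

Hydrogen in place of the 2H-tetrazol-5-yl group on an aromatic carbon, meta to a large group, gives a 2.4-fold higher number from compound 2 to compound 4 (0.38 log units; beyond the scatter) in this assay, and this is the only step in the set where a single change can be read on its own. The step is modest but lies beyond the scatter, so the 2H-tetrazol-5-yl group at this place does count in the read-out, although the two groups of compound 2 are not both needed for an effect: compound 4, which keeps the other 2H-tetrazol-5-yl group, still gives 38.1 mg/kg on this read-out. The data offer no measured finding that would explain the size of this step.

The compounds shown leave open whether an amine or a nitrile on this same aromatic carbon would behave like the 2H-tetrazol-5-yl group or like hydrogen. They also leave open what taking away the other 2H-tetrazol-5-yl group alone would do, and whether a step of that kind would match the one seen here.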